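From 4-hydroxyphenyl to 2,6-dimethoxyphenyl: a small expected step

The source may report more compounds than this note shows. Statements on the series, on what has been measured and on what is new or still open speak of the compounds shown alone.

In a functional assay on HCC 2998 cells (Homo sapiens) for inhibition, read by sulforhodamine B assay, with a stated time of 48 h (a lower number here means a stronger inhibitor of growth, a higher number a weaker inhibitor of growth), compound 1 `O=C(Cc1csc2nc(-c3ccc(Br)cc3)cn12)N/N=C/c1ccccc1O` gives 12600 nM while compound 2 `O=C(Cc1csc2nc(-c3ccc(Br)cc3)cn12)N/N=C/c1ccc(O)cc1` gives 29500 nM and so stands at the higher of the two numbers. Compound 3 `COc1cccc(OC)c1/C=N/NC(=O)Cc1csc2nc(-c3ccc(Br)cc3)cn12` departs from compound 2 in one place (2,6-dimethoxyphenyl in place of 4-hydroxyphenyl on a carbon with a double bond to nitrogen) with 2,6-dimethoxyphenyl in place of 4-hydroxyphenyl on a carbon with a double bond to nitrogen. Among the compounds with values here, only one measured step bears on this change, a 2.3-fold higher number from compound 1 to compound 2 (0.37 log units; beyond the scatter) when 4-hydroxyphenyl replaces 2-hydroxyphenyl at that same place. Within the data shown here, no compound with 2,6-dimethoxyphenyl has been measured, so that step offers a scale and little more. Taking it as the only guide, an estimated 1.5-fold lower number from compound 2 to compound 3 (0.17 log units; within the scatter) is expected in this assay as a small move towards a lower number, not clearly beyond the scatter. Compound 3 is estimated at 20000 nM (expected range 8000 nM to 50000 nM).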

Compound 3, concentration for total growth inhibition: 34700 nM
For compound 3 the middle estimate is 1.7-fold (0.24 log units) below the measured one, within the range that was stated.
By their numbers in this assay, from the lowest: compound 1; then compounds 2 and 3 (each within the scatter of the next).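

In this assay, the swap of 4-hydroxyphenyl for 2,6-dimethoxyphenyl gives a 1.2-fold higher number from compound 2 to compound 3 (0.07 log units; within the scatter) and so does not separate these two groups at this place, although the hydroxy group is gone and methoxy groups have come in. Measured against 2-hydroxyphenyl, the same group gives a 2.8-fold higher number from compound 1 to compound 3 (0.44 log units; beyond the scatter) and leaves compound 1 alone at the lowest number, while compound 2 and compound 3 cannot be told apart. No measured evidence accounts for this result.

The compounds shown leave open whether the lower number of compound 1 depends on the hydroxy group itself or would also be seen with 2-aminophenyl at this place. They also leave open how a carboxylic acid on the phenyl ring would read in this assay.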